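The source may report more compounds than this note shows. Statements on the series, on what has been measured and on what is new or still open speak of the compounds shown alone.

Of the compounds shown here, three built on one shared core have been measured in a functional assay on SK-BR-3 cells (Homo sapiens) for inhibition, read by MTT assay, with a stated time of 2 days, tested at 100 uM; a higher number here means more inhibition of growth at the concentration tested, a lower number less inhibition of growth. Compound 1 `CNC(=O)c1cc(Oc2ccc3nc(NC(=O)Nc4ccc(Cl)cc4)sc3c2)ccn1` gives 77.4%, compound 2 `CNC(=O)c1cc(Oc2ccc3nc(NC(=O)Nc4ccc(C5CCN(C(C)C)CC5)cc4)sc3c2)ccn1` gives 91.6%, and compound 3 `CNC(=O)c1cc(Oc2ccc3nc(NC(=O)Nc4ccc(Br)cc4)sc3c2)ccn1` gives 69.2%. Compound 3 thus holds the lowest of the three numbers, but its nearest neighbour, compound 1, sits within the scatter of it, as the step of a number 8.2 percentage points lower from compound 1 to compound 3 (within the scatter) shows. Only compound 2 stands clearly apart, seen in the step of a number 22.4 percentage points lower from compound 2 to compound 3 (beyond the scatter) and, from the other side, in the step of a number 14.2 percentage points higher from compound 1 to compound 2 (beyond the scatter).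

Compound 4 `CNC(=O)c1cc(Oc2ccc3nc(NC(=O)Nc4ccc(F)cc4)sc3c2)ccn1` differs from compound 3 in a single place: fluoro in place of bromo on an aromatic carbon. Going by the values given here, the one measured step that bears on swapping one halogen for another at this position is a number 8.2 percentage points lower from compound 1 to compound 3 (within the scatter), and it stayed within the scatter. Among the compounds with values here, no measured step involves fluoro, so nothing argues for a clear move in either direction in this assay. Compound 4 is therefore expected to give about 72%, with a range from 55% to 88%. The step of a number 2.8 percentage points higher from compound 3 to compound 4 (within the scatter) this estimate implies is expected to stay within the scatter.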

Compound 4, percent growth inhibition at one concentration: 72.9%
Estimate against measurement, compound 4: 0.9 percentage points below, within the range that was stated.
By their numbers in this assay, from the lowest: compounds 3, 4 and 1 (each within the scatter of the next); then compound 2.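

In this assay, fluoro in place of bromo (a number 3.7 percentage points higher from compound 3 to compound 4 (within the scatter)) and fluoro in place of chloro (a number 4.5 percentage points lower from compound 1 to compound 4 (within the scatter)) both stay within the scatter, so compounds 1, 3 and 4 now form a set of three halogens that this read-out cannot tell apart. Going by these compounds alone, the 1-isopropylpiperidin-4-yl group stands apart from fluoro as well (a number 18.7 percentage points lower from compound 2 to compound 4 (beyond the scatter)), so among the four compounds only that group gives a clear difference at this position. Nothing available explains why the halogens group together or why compound 2 stands apart.

As far as these compounds go, whether a simple amine such as dimethylamino, or a carboxylic acid, at this position would fall with the halogens or with compound 2 remains open. Also open, from the compounds shown here alone, is whether the gap would hold at lower concentrations or in other cell lines.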